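This account rests on a few compounds, and the source may have more. Where it says the series, first, only, none or still open, it means among the compounds named here.

Measured so far in a physicochemical assay for acid dissociation, using potentiometric titration:

compound 1 `N#C/C(=N\O)C(=O)Nc1cccc(C(F)(F)F)c1` — 4.88
compound 2 `N#C/C(=N\O)C(=O)Nc1cc(C(F)(F)F)cc(C(F)(F)F)c1` — 4.73

In this assay compound 1 gives 4.88 and compound 2 gives 4.73; the two lie within the scatter of each other, so compound 1 cannot be placed above or below compound 2, only beside it. Among the measured compounds shown here, the one measured step, a number 0.15 log units lower from compound 1 to compound 2 (within the scatter), came with trifluoromethyl in place of hydrogen on an aromatic carbon.

Compound 3 `N#C/C(=N\O)C(=O)Nc1cccc(F)c1` has not yet been measured. It differs from compound 1 by fluoro in place of trifluoromethyl on an aromatic carbon. For the measured compounds named here, the only step that bears on a change at an aromatic carbon of the shared core is the one from compound 1 to compound 2, and that stayed within the scatter. A swap of one substituent for another at the same aromatic position is therefore not expected to move the read-out beyond the scatter either, in either direction.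

Compound 3 is expected at 4.93, with a range from 4.65 to 5.25. The step this estimate means is a number 0.05 log units higher from compound 1 to compound 3 (within the scatter), expected to fall inside the scatter.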

Compound 3, acid dissociation constant: 4.92
For compound 3 the middle estimate is 0.01 log units above the measured one; low and high end bracket the measured number.
By their numbers in this assay, from the lowest: compounds 2, 1 and 3 (each within the scatter of the next).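

At the aromatic carbon that carries trifluoromethyl in compound 1, fluoro in place of trifluoromethyl gave a number 0.04 log units higher from compound 1 to compound 3 (within the scatter) in this assay. The earlier step put a second trifluoromethyl on another aromatic carbon, whereas this one exchanges the group at the same position for one with fewer heavy atoms, and this exchange also leaves the two compounds indistinguishable in the read-out. No supporting measurement is available to interpret this result.

The compounds shown carry only trifluoromethyl and fluoro on the aromatic ring, so it remains open whether an amine, a carboxylic acid or a longer chain at this position would give a step beyond the scatter. What a change at the nitrile or the carbonyl of the shared core would do in this assay also stays open, since both groups are the same in all the compounds shown.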